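This account rests on a few compounds, and the source may have more. Where it says the series, first, only, none or still open, it means among the compounds named here.

Working notes on the series. Compound 1 `Cc1c(O)ccc2c1[C@H](Cn1cc(-c3ccc(F)cc3)nn1)[C@@]13CC(=O)[C@@](C)(CC[C@@H]21)C3` has a free hydroxyl on the shared core, while compound 2 `Cc1ccc(S(=O)(=O)Oc2ccc3c(c2C)[C@H](Cn2cc(-c4ccccn4)nn2)[C@@]24CC(=O)[C@@](C)(CC[C@@H]32)C4)cc1` and compound 3 `Cc1ccc(S(=O)(=O)Oc2ccc3c(c2C)[C@H](Cn2cc(-c4ccc(Br)cc4)nn2)[C@@]24CC(=O)[C@@](C)(CC[C@@H]32)C4)cc1` carry the larger sulfonate group there and differ only in the aryl group on the triazole. In a functional assay on SMMC-7721 cells (Homo sapiens) for cytotoxicity, read by MTT assay, with a stated time of 4 days (a lower number here means a stronger inhibitor, a higher number a weaker inhibitor), compound 1 returns only a limit of the assay, > 20000 nM. In this assay compound 2 likewise returns a limit, > 20000 nM. Compound 3 also returns a limit, > 20000 nM. Going by the values given here, the single measured step, a step that the two limits leave unreadable from compound 2 to compound 3, cannot be sized, as both ends sit at the limit of > 20000 nM in this assay, at which 3 of the 3 values shown sit. Compound 3 therefore stands at the limit together with every other measured compound, with no ordering readable among them.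

Compound 4 `Cc1ccc(S(=O)(=O)Oc2ccc3c(c2C)[C@H](Cn2cc(-c4ccc(F)cc4)nn2)[C@@]24CC(=O)[C@@](C)(CC[C@@H]32)C4)cc1` differs from compound 3 by fluoro in place of bromo on an aromatic carbon. Among the compounds with values here, no measured step bears directly on this exchange. The 4-fluorophenyl group occurs only in compound 1, which carries the hydroxyl instead of the sulfonate, and compound 1 sits at the limit. The step that the two limits leave unreadable from compound 2 to compound 3, exchanging one aryl group for another on the same core, left both compounds at the limit and gives no direction. Compound 4 is thus expected to stay at the limit, and the expected step that the limit leaves unreadable from compound 3 to compound 4 is none beyond the scatter. The estimate for compound 4 is 30000 nM, with a range from 10000 nM to 100000 nM.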

Compound 4, half-maximal inhibitory concentration: > 20000 nM
Compound 4: no number, only a limit; the forecaster's own chance of this, stated with the estimate: 85%; the middle value is on the limit's open side.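

In this assay compound 4 also returns only a limit of the assay, > 20000 nM. Going by these compounds alone, no step from compound 1, compound 2 or compound 3 to compound 4 can be read, as both ends of each sit at the same limit: the limit of > 20000 nM in this assay, at which 4 of the 4 values shown sit. The compounds shown leave open how any of these aryl or sulfonate exchanges would register in this assay, since none gives a number.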